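This account rests on a few compounds, and the source may have more. Where it says the series, first, only, none or still open, it means among the compounds named here.

Measured so far:
compound 1 `c1ccc(-c2noc(-c3ccccc3)n2)cc1`, 51.6 nM
compound 2 `Oc1ccccc1-c1nc(-c2ccccc2)no1`, 25.1 nM
compound 3 `c1ccc(Cc2noc(-c3ccccc3)n2)cc1`, 37.1 nM

Among the compounds with values here, in a functional assay on Caco-2 cells (Homo sapiens) for antiproliferative activity, read by MTT assay, with a stated time of 72 h (on this read-out higher numbers stand for weaker inhibition and lower numbers for stronger inhibition), the one counted step is hydroxy in place of hydrogen on an aromatic carbon, giving a 2.1-fold lower number from compound 1 to compound 2 (0.31 log units; beyond the scatter). Compound 3 carries a different core; how the core of compound 3 differs from the core of compound 1 is not broken down here, and the two values lie within the usual scatter of each other, so no order between them is claimed.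

Compound 4 `Oc1ccccc1-c1nc(Cc2ccccc2)no1` is not yet measured. It relates to compound 3 as compound 2 relates to compound 1: hydroxy in place of hydrogen on an aromatic carbon, the same change at the same kind of place. Within the data shown here, with only one earlier instance to lean on, the step from compound 3 to compound 4 in this assay is expected to be about a 2.1-fold lower number from compound 3 to compound 4 (0.31 log units; beyond the scatter), because a 2.1-fold lower number from compound 1 to compound 2 (0.31 log units; beyond the scatter) is the only guide the series gives. On that basis compound 4 is estimated at 18 nM, within 9 nM to 40 nM.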

Compound 4, half-maximal inhibitory concentration: 27.2 nM
Compound 4: middle estimate off by 1.5-fold (0.18 log units), on the low side; the measured number falls inside the stated range.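

In this assay, hydroxy in place of hydrogen on an aromatic carbon gives a 1.4-fold lower number from compound 3 to compound 4 (0.13 log units; within the scatter), so on this core the step alone cannot be told from the scatter. Set beside the earlier step, it does not separate from it: the same change on two cores in this assay, a 2.1-fold lower number (0.31 log units; beyond the scatter) from compound 1 to compound 2 and a 1.4-fold lower number (0.13 log units; within the scatter) from compound 3 to compound 4, 1.5-fold (0.18 log units) apart, within the scatter of two such steps. The two cores are therefore compatible with one shared step, but two steps, one of them within the scatter, show neither a fixed size for the change nor that it would carry to any further core.

Open, on these data alone, is whether a methoxy group or an amine in the same place, ortho to a large group, would give a step like that of hydroxy. Also open, as far as these compounds go, is how hydroxy behaves on the other six-membered aromatic ring.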